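This account rests on a few compounds, and the source may have more. Where it says the series, first, only, none or still open, it means among the compounds named here.

The series rests on a shared core, seen in compound 1 `CCCCC1=C(Br)/C(=C/Br)OC1=O`, compound 2 `CCC[C@@H](O)C1=C(Br)C(=C(Br)Br)OC1=O` and compound 3 `CCC[C@@H](O)C1=C(Br)/C(=C\Br)OC1=O`. In a functional assay on KB cells (Homo sapiens) for cytotoxicity (a higher number here means that more compound is needed for the effect, a lower number that less compound is needed), compound 1 gives > 20 ug/mL, which is a limit of the assay rather than a number. Compound 1 thus sits at the limit of > 20 ug/mL in this assay, at which 1 of the 3 values shown sits. Compound 2 gives 0.5 ug/mL in this assay. Compound 3 gives 0.5 ug/mL in this assay and so stands level with compound 2 at the digits shown; the two values lie within the usual scatter of each other, and no order between them can be read. The next member, compound 4 `CCC[C@@H](O)C1=C(Br)/C(=C/Br)OC1=O`, has not yet been measured. Compared with compound 3, the change is this: the two compounds have the same atoms and bonds and differ only in configuration as drawn: 1 of 2 stereo elements differ; a double bond is drawn E in compound 3 and Z in compound 4. Among the compounds with values here, no step between two measured compounds shows what such a change of configuration does, and compound 1 and compound 3 show only a limit and a number without a counted difference between them. One would therefore expect compound 4 to remain close to compound 3 in this assay, with a modest step toward a higher concentration, a 2.0-fold higher number from compound 3 to compound 4 (0.30 log units; within the scatter), hardly beyond the scatter. Compound 4 is estimated at 1 ug/mL, with a range from 0.3 ug/mL to 5 ug/mL.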

Compound 4, concentration for half-maximal effect: 0.4 ug/mL
Compound 4: the middle estimate sits 2.5-fold (0.40 log units) above what was measured; low and high end bracket the measured number.
By their numbers in this assay, from the lowest: compounds 4, 2 and 3 (each within the scatter of the next). At a limit, above all of these: compound 1.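

In this assay the double bond drawn E or Z now has a counted step (a 1.3-fold lower number from compound 3 to compound 4 (0.10 log units; within the scatter)), and for this one pair the change of configuration stays within the scatter. The value of compound 1 is a limit of the assay and not a number: the limit of > 20 ug/mL in this assay, at which 1 of the 4 values shown sits. Within the data shown here, the step for hydroxy in place of hydrogen on a saturated chain carbon bound to a double-bonded ring carbon and a saturated chain carbon (an at least 50-fold lower number from compound 1 to compound 4 (1.69 log units; beyond the scatter)) is large and beyond the scatter, whereas the earlier compounds gave only a limit and a number without a counted difference for this change.

Whether the double bond's configuration would matter as little with the opposite configuration at the hydroxy-bearing carbon stays open, since that carbon is drawn one way throughout the compounds shown. What a methoxy group, an amine or a carboxylic acid in place of the hydroxy, or a longer chain, would do to the value in this assay also remains unanswered.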